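Benzylamino Nucleosides at the Edge of Measurement

The source may hold more compounds than are shown below. What is called first, only, known or untested is meant among the compounds shown, and "the series" means these compounds.

Compound 1 `COc1cccc(CNc2ncnc3c2ncn3[C@@H]2O[C@H](CO)[C@@H](O)[C@H]2O)c1` bears a 3-methoxybenzyl group on a nitrogen of the shared core. In a functional assay on HOS cells (Homo sapiens) for antiproliferative activity, with a stated time of 72 h (on this read-out higher numbers stand for weaker inhibition and lower numbers for stronger inhibition), compound 1 gives > 166000 nM, which is a limit of the assay and not a number. Compound 3 `COc1ccc(CNc2ncnc3c2ncn3C2OC(CO)[C@@H](O)[C@H]2O)c(O)c1` is a close relative with a different substitution pattern on its benzyl ring. In this assay compound 3 gives > 166000 nM, again a limit of the assay. Compound 2 `OC[C@H]1O[C@@H](n2cnc3c(NCc4cc(F)cc(F)c4)ncnc32)C(O)C1O` is recorded in this assay as "not determined" (no result reported). Compound 1 therefore stands at the limit of > 166000 nM in this assay, at which 2 of the 3 values shown sit, with no numbered value anywhere in the set to measure it against.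

Compound 4 `Cc1ccc(O)c(CNc2ncnc3c2ncn3[C@@H]2O[C@H](CO)[C@@H](O)[C@H]2O)c1` differs from compound 1 in one place: 2-hydroxy-5-methylphenyl in place of 3-methoxyphenyl on a saturated chain carbon bound to a nitrogen on an aromatic ring. Within the data shown here, no step between two measured compounds is available here, so the size of such a change cannot be read from these data. Compound 4 is expected to remain at the limit, with an estimated 200000 nM and a range from 50000 nM to 800000 nM. The step that the limit leaves unreadable from compound 1 to compound 4 is expected to be none beyond the scatter, its direction being unknowable while compound 1 itself is only a limit.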

Compound 4, half-maximal inhibitory concentration: > 166000 nM
Compound 4 gave a limit, no number; the forecaster's own chance of this, stated with the estimate: 80%; the middle value does not contradict the limit.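

Among these compounds, no step from compound 1 to compound 4 can be read, as each stands only at a limit of this assay; the set remains held at that limit: the limit of > 166000 nM in this assay, at which 3 of the 4 values shown sit. The compounds shown leave open whether any benzyl group on the shared core gives a numbered value in this assay.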